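Cytotoxicity of compound 4, expected from three measured compounds

The compounds below may be only part of what the source reports. "The series", "measured", "known", "first", "only" and "open" are said of these compounds alone.

Compound 3 `CN(C)S(=O)(=O)NC[C@H]1CN(c2ccc(-n3cc(-c4ccccn4)cn3)c(F)c2)C(=O)O1` stands alone among the three measured compounds in giving an actual number in an ADME assay on L02 cells (Homo sapiens) for cytotoxicity, read by MTT assay, with a stated time of 48 h; a lower number here means a stronger inhibitor, a higher number a weaker inhibitor: compound 3 gives 158 ug/mL. Compound 1 `O=C1O[C@@H](CSc2cccs2)CN1c1ccc(-n2cc(-c3ccccn3)cn2)c(F)c1` gives > 400 ug/mL, which is a limit of the assay and not a number. Compound 2 `O=CNC[C@H]1CN(c2ccc(-n3cc(-c4ccccn4)cn3)c(F)c2)C(=O)O1` likewise gives > 400 ug/mL, again a limit. Two of the three values therefore sit at the limit of > 400 ug/mL in this assay, at which 2 of the 3 values shown sit. The step that the two limits leave unreadable from compound 1 to compound 2 cannot be read. The step of an at least 2.5-fold lower number from compound 1 to compound 3 (0.40 log units; beyond the scatter) and the step of an at least 2.5-fold lower number from compound 2 to compound 3 (0.40 log units; beyond the scatter) both run toward the dimethylsulfamoyl-bearing compound 3 and both lower the number.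

Compound 4 `CONC(=O)[C@H]1CN(c2ccc(-n3cc(-c4ccccn4)cn3)c(F)c2)C(=O)O1` differs from compound 3 by methoxycarbamoyl in place of ((dimethylsulfamoyl)amino)methyl on a saturated ring carbon. The two readable steps bear on it in the reverse sense: removing the (dimethylsulfamoyl)amino group from compound 3, whether toward the (thiophen-2-yl)sulfanyl of compound 1 or the formylamino of compound 2, returned the value to the limit. Compound 4 also lacks that group, so a rise in this assay of at least modest size is expected. The step of a 2.1-fold higher number from compound 3 to compound 4 (0.32 log units; beyond the scatter) is the estimate, with a fair chance that only a limit is reported. Compound 4 is accordingly expected to give 330 ug/mL, within 140 ug/mL to 800 ug/mL.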

Compound 4, half-maximal inhibitory concentration: > 400 ug/mL
Compound 4: no number, only a limit; the forecaster's own chance of this, stated with the estimate: 55%; middle value at least 1.2-fold (0.08 log units) away from the limit.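

In this assay, the change on this saturated ring carbon, next to the ring oxygen, gives an at least 2.5-fold higher number from compound 3 to compound 4 (0.40 log units; beyond the scatter). Among the compounds shown here, compound 4 is the first compound here whose group at this place is not a substituted methyl, and it falls with compound 1 and compound 2 rather than with compound 3, so among the four compounds only the ((dimethylsulfamoyl)amino)methyl of compound 3 gives an actual number. The steps from compound 1 and from compound 2 to compound 4 cannot be read, and these three compounds cannot be ordered against one another: the limit of > 400 ug/mL in this assay, at which 3 of the 4 values shown sit.

The compounds shown leave open how far the true values of compound 1, compound 2 and compound 4 lie from that limit, and whether the number of compound 3 depends on the whole dimethylsulfamoyl group or would also appear with a methanesulfonyl group on the same amine nitrogen or with a plain aminomethyl. They also leave open whether a carboxylic acid or an unsubstituted carbamoyl in place of the methoxycarbamoyl of compound 4 would stay at the limit.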